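The source may report more compounds than this note shows. Statements on the series, on what has been measured and on what is new or still open speak of the compounds shown alone.

Compound 1 `N#C/C(=C\c1c(F)c(F)c(F)c(F)c1F)C(=O)c1ccc[nH]1` was tested in a functional assay on SMA cells (Homo sapiens) for inhibition, read by MTT assay, with a stated time of 72 h (a higher number here means a weaker inhibitor of growth, a lower number a stronger inhibitor of growth), and reached only a limit of the assay, > 100000 nM. Going by the values given here, compound 2 `COc1ccc(CNC(=O)/C(C#N)=C/c2ccc(Cl)o2)cc1` gave 14000 nM in this assay, and it is the only compound of the three measured for which a number rather than a limit is in hand. Compound 3 `COc1ccc(CNC(=O)/C(C#N)=C/c2ccc(-c3ccccc3)o2)cc1` likewise reached only a limit in this assay, > 100000 nM. Among the compounds with values here, the one step between measured compounds, an at least 7.1-fold higher number from compound 2 to compound 3 (0.85 log units; beyond the scatter), puts phenyl in place of chloro on an aromatic carbon, and its size cannot be stated more closely because it runs into (the limit of > 100000 nM in this assay, at which 2 of the 3 values shown sit). Compound 4 `COc1ccc(CNC(=O)/C(C#N)=C/c2ccc(Cl)cc2)cc1` differs from compound 2 in another way: 4-chlorophenyl in place of 5-chlorofuran-2-yl on a double-bonded chain carbon bound to a double-bonded chain carbon. Within the data shown here, no measured step exchanges the ring itself, so the step from compound 2 to compound 3 bears on this change only loosely, showing that a change on the furan ring of compound 2 weakened growth inhibition beyond the scatter. Since compound 4 keeps the chloro and alters the aromatic ring alone, no step beyond the scatter is expected in this assay in either direction, though a weaker result remains possible. The estimate for compound 4 is 20000 nM, within 5000 nM to 90000 nM, corresponding to an expected step of a 1.4-fold higher number from compound 2 to compound 4 (0.15 log units; within the scatter).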

Compound 4, concentration for 50% growth inhibition: 17000 nM
Compound 4: the middle estimate sits 1.2-fold (0.07 log units) above what was measured; measured number inside the range.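

Going by these compounds alone, with 4-chlorophenyl in place of 5-chlorofuran-2-yl on a double-bonded chain carbon bound to a double-bonded chain carbon, this assay gives a 1.2-fold higher number from compound 2 to compound 4 (0.08 log units; within the scatter), and this is the first measured step that exchanges the ring itself. At this position, therefore, the five-membered aromatic ring with 1 hetero atom and the six-membered aromatic ring of carbon only cannot be told apart when each carries chloro, and the hydrogen-bond acceptor counted for the furan ring can be lost without a step beyond the scatter. Within the data shown here, the earlier compounds showed only that a change on the furan ring of compound 2 could weaken growth inhibition, whereas compound 4 shows that the ring can be exchanged with a measured number retained, so that two of the compounds now have a number rather than a limit.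

As far as these compounds go, whether an amine or a carboxylic acid in place of the chloro of compound 4 would keep a measured number in this assay stays open. Whether phenyl in place of that chloro would weaken growth inhibition as it did on the furan ring also stays open, and the size of the earlier step remains bounded on one side only: the limit of > 100000 nM in this assay, at which 2 of the 4 values shown sit.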